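Swapping Bromo for Methyl on Compound 2

This account rests on a few compounds, and the source may have more. Where it says the series, first, only, none or still open, it means among the compounds named here.

In an ADME assay on NIH3T3 cells (Mus musculus) for cytotoxicity, read by MTT assay, with a stated time of 24 h (a higher number here means a weaker inhibitor, a lower number a stronger inhibitor), compound 2 `Cn1nnnc1SCC(=O)N/N=c1/scc(-c2ccc(Br)cc2)n1-c1ccccc1` gives 19.3 ug/mL. Among the compounds with values here, that is the lowest of the two numbers known so far; its nearest neighbour, compound 1 `Cc1ccc(-c2cs/c(=N/NC(=O)CSc3nncn3C)n2-c2ccccc2)cc1`, gives 130 ug/mL in this assay, a gap beyond the scatter. Compound 3 `Cc1ccc(-c2cs/c(=N/NC(=O)CSc3nnnn3C)n2-c2ccccc2)cc1` has not yet been measured in this assay. It differs from compound 2 in one place: methyl in place of bromo on an aromatic carbon. Within the data shown here, no measured pair shows this exact step, so its size is open. Among the measured compounds shown here, the only guide is compound 1, which also bears a methyl rather than a bromo and gives 130 ug/mL in this assay. On that basis the step is expected to be a 3.1-fold higher number from compound 2 to compound 3 (0.49 log units; beyond the scatter), a rise beyond the scatter toward weaker inhibition. Compound 3 is therefore estimated at 60 ug/mL, with a range from 25 ug/mL to 150 ug/mL.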

Compound 3, half-maximal inhibitory concentration: 243 ug/mL
Beside the measured number, compound 3's estimate is 4.1-fold (0.61 log units) below it; the measured number lies above the stated range.
By their numbers in this assay, from the lowest: compound 2; then compounds 1 and 3 (each within the scatter of the next).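

In this assay, the change from 4-bromophenyl to 4-methylphenyl now stands alone on one shared core, and it is large, with a 13-fold higher number from compound 2 to compound 3 (1.10 log units; beyond the scatter) for this single change. Compound 1 could not show this, as it differs from compound 2 in two places. With the 4-methylphenyl group held fixed, putting 1-methyl-1H-tetrazol-5-yl in place of 4-methyl-4H-1,2,4-triazol-3-yl on the sulfur gives a 1.9-fold higher number from compound 1 to compound 3 (0.27 log units; within the scatter) in this pair, so the gap between compound 2 and the other two follows the bromo group in the compounds shown. Nothing available explains why this one exchange has so large a step.

As far as these compounds go, whether the step keeps its size with 4-methyl-4H-1,2,4-triazol-3-yl on the sulfur stays open. So does whether a chloro, methoxy or amino group on that aromatic carbon would read like bromo or like methyl.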